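A few compounds are considered here, and "the series" means these few. Any claim that something is new, unique, unknown or untested is made for them only; others in the source may bear on it.

In a functional assay on ECa-109 cells for inhibition, with ECa-109 cell line (Homo sapiens) as the target, read by sulforhodamine B assay (a lower number here means a stronger inhibitor, a higher number a weaker inhibitor), compound 1 `COc1ccc(NC2=CC(=O)c3c(nc4n3[C@H]3OC[C@@H](O)[C@H]3OC4)C2=O)cc1`, which carries (4-methoxyphenyl)amino on the shared core, gives 3410 nM. Compound 2 `CCCN(CCC)C1=CC(=O)c2c(nc3n2[C@H]2OC[C@@H](O)[C@H]2OC3)C1=O`, with dipropylamino at that place, reads > 16000 nM, which is a limit of the assay and not a number. Compound 3 `O=C1C(Nc2cccc(Cl)c2)=CC(=O)c2c1nc1n2[C@H]2OC[C@@H](O)[C@H]2OC1` has (3-chlorophenyl)amino in place of dipropylamino on a double-bonded ring carbon, a change counted as (3-chlorophenyl)amino in place of dipropylamino on a double-bonded ring carbon. Going by the values given here, one measured step bears on this: an at least 4.6-fold higher number from compound 1 to compound 2 (0.67 log units; beyond the scatter). That step exchanged a substituted phenylamino group for dipropylamino, and compound 3 makes the exchange in the opposite direction, with a different substituted phenyl ring. A step of at least similar size towards a lower number is therefore expected in this assay. The expected move is an at least 4.5-fold lower number from compound 2 to compound 3 (0.66 log units; beyond the scatter). For compound 3 the estimated value is 3500 nM, with an expected range from 1000 nM to 12000 nM.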

Compound 3, half-maximal inhibitory concentration: 3080 nM
Beside the measured number, compound 3's estimate is 1.1-fold (0.06 log units) above it, and the stated range covers the measured number.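

In this assay, (3-chlorophenyl)amino in place of dipropylamino on the double-bonded ring carbon gives an at least 5.1-fold lower number from compound 2 to compound 3 (0.71 log units; beyond the scatter). The size of that step has only a bound, since compound 2 stands at a limit of the assay and not at a number: the limit of > 16000 nM in this assay, at which 1 of the 3 values shown sits.

With 3-chlorophenyl in place of 4-methoxyphenyl on the amine nitrogen, the pair gives a 1.1-fold lower number from compound 1 to compound 3 (0.04 log units; within the scatter), so these two substituted phenyl rings cannot be told apart by this assay, and both phenylamino compounds differ from compound 2 by steps beyond the scatter.

Whether the phenyl ring or the hydrogen on the amine nitrogen accounts for the gap to compound 2 stays open, and a propylamino group, which keeps that hydrogen without the ring, would separate the two. Also open, as far as these compounds go, is how an unsubstituted phenylamino or a benzylamino group would read at this place.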